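Lengthening a Saturated Chain by One Carbon

A few compounds are considered here, and "the series" means these few. Any claim that something is new, unique, unknown or untested is made for them only; others in the source may bear on it.

Of the compounds shown here, three sharing one core have been measured in an assay on membranes from Sf9 cells for displacement of a labelled ligand from histamine H2 receptor (Homo sapiens), read by scintillation counting, with a stated time of 60 min; on this read-out lower numbers stand for stronger inhibition and higher numbers for weaker inhibition. Compound 1 `Cc1nc(N)sc1CCCN/C(N)=N/C(=S)NC(c1ccccc1)c1ccccc1` gives 603 nM. Compound 3 `Cc1nc(N)sc1CCCN/C(N)=N/C(=O)NCC(C)CCc1ccccc1` gives 63.1 nM. Compound 2 `CCCCCNC(=O)/N=C(\N)NCCCc1sc(N)nc1C` gives 4.47 nM, the lowest of the three numbers; its nearest neighbour, compound 3, stands at a higher number beyond the scatter, and compound 1 stands further away still.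

Compound 4 `CCCCCCNC(=O)/N=C(\N)NCCCc1sc(N)nc1C` has not yet been measured. It differs from compound 2 in one place: methyl in place of hydrogen on a saturated chain carbon, five bonds along the chain from an amide-type nitrogen. Within the data shown here, no pair of measured compounds differs in only one place, so nothing measured here shows directly what such a change does. Because compound 2 already gives 4.47 nM and the change is a single added carbon on a saturated chain, the expected step in this assay is small, in either direction, and not beyond the scatter.

Compound 4 is therefore expected to give about 5 nM, within a range from 2 nM to 12.5 nM. The expected step of a 1.1-fold higher number from compound 2 to compound 4 (0.05 log units; within the scatter) is estimated to stay within the scatter.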

Compound 4, inhibition constant: 28.8 nM
Compound 4: middle estimate off by 5.8-fold (0.76 log units), on the low side; the whole stated range lies below it.
By their numbers in this assay, from the lowest: compound 2; then compound 4; then compound 3; then compound 1.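

Methyl in place of hydrogen on a saturated chain carbon, five bonds along the chain from an amide-type nitrogen, is the first single change that can be read in this assay, and it brings a 6.4-fold higher number from compound 2 to compound 4 (0.81 log units; beyond the scatter). This position is therefore not indifferent to chain length: one added carbon, with no ring, no hydrogen-bond donor or acceptor and no net charge, is enough to shift the read-out towards weaker inhibition by a modest amount that exceeds the scatter. Nothing shown here gives a reason for this step.

A single step cannot show whether a still longer chain would continue in the same direction or whether a shorter chain would give a lower number. It also leaves open how a hydroxyl or an amine at the end of the chain would compare with the added methyl.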